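Working notes: from compound 3 to compound 4

A few compounds are considered here, and "the series" means these few. Any claim that something is new, unique, unknown or untested is made for them only; others in the source may bear on it.

Measured so far in an ADME assay on a cell-free system (plasma, Homo sapiens) for metabolic stability, read by LC-MS; a lower number here means that the compound disappears faster, a higher number that the compound lasts longer:
- compound 1 `CCCCOC(=O)c1cccc(-c2cc(C(=O)Nc3ccncc3)ccc2CN)c1`: 0.367 h
- compound 2 `NCc1ccc(C(=O)Nc2ccncc2)cc1-c1cccc(C(=O)OCC2CCCCC2)c1`: 1.65 h
- compound 3 `NCc1ccc(C(=O)Nc2ccncc2F)cc1-c1cccc(C(=O)OCC2CC2)c1`: 0.3 h

Compound 3 at 0.3 h lies within the scatter of compound 1 at 0.367 h. Compound 2 at 1.65 h has the higher number, beyond the scatter of both. Compound 4 `NCc1ccc(C(=O)Nc2ccncc2F)cc1-c1cccc(C(=O)OCCO)c1` carries hydroxymethyl in place of cyclopropyl on a saturated chain carbon bound to an oxygen next to a carbonyl group. For the measured compounds named here, one measured step bears on this place, a 4.5-fold higher number from compound 1 to compound 2 (0.65 log units; beyond the scatter), where cyclohexyl replaces propyl. It shows that this assay can respond to a change here, but it was measured on the core of compound 1 and involves no hydroxymethyl. It therefore gives only weak guidance on size and direction. No step beyond the scatter is expected, with a slight lean towards a lower number. The expected step is a 1.4-fold lower number from compound 3 to compound 4 (0.13 log units; within the scatter). For compound 4 the estimate is 0.22 h, with an expected range of 0.07 h to 0.65 h.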

Compound 4, half-life: 1.35 h
For compound 4 the middle estimate is 6.1-fold (0.79 log units) below the measured one, outside the stated range (above it).
By their numbers in this assay, from the lowest: compounds 3 and 1 (each within the scatter of the next); then compounds 4 and 2 (each within the scatter of the next).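

In this assay, a 4.5-fold higher number from compound 3 to compound 4 (0.65 log units; beyond the scatter) shows that this position responds on the core of compound 3 as well, and that the change from cyclopropyl to hydroxymethyl moves the number beyond the scatter. Together with a 4.5-fold higher number from compound 1 to compound 2 (0.65 log units; beyond the scatter), it shows that a higher number here can come with two unlike changes: one brings in a cyclohexyl ring, while the other removes a ring and brings in a hydrogen-bond donor and acceptor. Nothing shown explains the rise from compound 3 to compound 4.

The compounds shown do not separate the contribution of the terminal hydroxyl from that of losing the cyclopropyl ring; a plain ethyl or methoxyethyl ester would bear on this. On these data alone, how an amine or a carboxylic acid at the end of this chain would behave also remains open.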